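From 2,3-dimethylphenyl to 2,3-dimethoxyphenyl: an expected small step

This account rests on a few compounds, and the source may have more. Where it says the series, first, only, none or still open, it means among the compounds named here.

Measured so far in a functional assay on A549 cells (Homo sapiens) for cytotoxicity, read by MTT assay, with a stated time of 48 h (a lower number here means a stronger inhibitor, a higher number a weaker inhibitor), are three compounds:
- compound 1 `CC1(C)CCC[C@]2(C)[C@@H](CC[C@@](C)(O)/C=C/c3ccccc3)[C@](C)(O)CC[C@@H]12` gives 3150 nM
- compound 2 `CC1(C)CCC[C@]2(C)[C@@H](CC[C@@](C)(O)/C=C/c3cncc4ccccc34)[C@](C)(O)CC[C@@H]12` gives 45700 nM
- compound 3 `Cc1cccc(/C=C/[C@](C)(O)CC[C@@H]2[C@@]3(C)CCCC(C)(C)[C@@H]3CC[C@@]2(C)O)c1C` gives 3800 nM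

Compound 3 stands level with compound 1 and far from compound 2. The first gap is a 1.2-fold higher number from compound 1 to compound 3 (0.08 log units; within the scatter) and the second is a 12-fold lower number from compound 2 to compound 3 (1.08 log units; beyond the scatter) on the same scale.

The next compound is compound 4 `COc1cccc(/C=C/[C@](C)(O)CC[C@@H]2[C@@]3(C)CCCC(C)(C)[C@@H]3CC[C@@]2(C)O)c1OC`, which keeps the shared core. The change from compound 3 is 2,3-dimethoxyphenyl in place of 2,3-dimethylphenyl on a double-bonded chain carbon bound to a double-bonded chain carbon and it sits on a double-bonded chain carbon bound to a double-bonded chain carbon.

Among the measured compounds shown here, two measured steps bear on this place. The closer precedent, a 1.2-fold higher number from compound 1 to compound 3 (0.08 log units; within the scatter) in size, swapped one aromatic ring of carbon only for another, as this change does. The other, a 15-fold higher number from compound 1 to compound 2 (1.16 log units; beyond the scatter) on going to isoquinolin-4-yl, shows that a swap here can matter greatly. For the measured compounds named here, no measured compound carries 2,3-dimethoxyphenyl, so the direction rests on little. A slight rise in the number is expected, and the expected step is a 1.4-fold higher number from compound 3 to compound 4 (0.16 log units; within the scatter) in this assay for now.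

In this assay compound 4 is estimated at 5500 nM with 1800 nM and 17000 nM as the ends of the expected range.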

Compound 4, half-maximal inhibitory concentration: 3280 nM
Beside the measured number, compound 4's estimate is 1.7-fold (0.22 log units) above it, within the range that was stated.
By their numbers in this assay, from the lowest: compounds 1, 4 and 3 (each within the scatter of the next); then compound 2.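

In this assay, this place on a double-bonded chain carbon bound to a double-bonded chain carbon now accepts a second kind of substituted ring with no reading change: 2,3-dimethoxyphenyl, which brings oxygen and hydrogen-bond acceptors that 2,3-dimethylphenyl lacks, gives (a 1.2-fold lower number from compound 3 to compound 4 (0.06 log units; within the scatter)), and set against plain phenyl it gives (a 1.0-fold higher number from compound 1 to compound 4 (0.02 log units; within the scatter)). Compound 1, compound 3 and compound 4, all with a six-membered aromatic ring of carbon only, therefore cannot be told apart here, whereas compound 2 goes against this grouping, as the large step to its isoquinolin-4-yl shows (a 14-fold lower number from compound 2 to compound 4 (1.14 log units; beyond the scatter)). Nothing at hand explains either the level readings or that large gap.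

The compounds shown leave open whether the large step follows the nitrogen of isoquinolin-4-yl or its second ring, a question that a naphthyl group, with two rings of carbon only, would help to separate. They also leave open whether an amine or a carboxylic acid on the phenyl ring would stay level with compound 1 and its relatives, or move the number as far as isoquinolin-4-yl does.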